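The source may hold more compounds than are shown below. What is called first, only, known or untested is meant among the compounds shown, and "the series" means these compounds.

The measured compounds and their values in a functional assay on isolated protein for agonist activity at Glucose-dependent insulinotropic receptor (Rattus norvegicus), read by HTRF and cAMP accumulation; on this read-out higher numbers stand for an effect only at larger amounts of compound and lower numbers for an effect already at smaller amounts:
compound 1 `CC(C)OC(=O)N1CCC(O[C@H]2CC[C@H](Oc3cnc(S(C)(=O)=O)cn3)CC2)CC1` gives 119 nM;
compound 2 `CS(=O)(=O)c1cnc(O[C@H]2CC[C@H](OC3CCN(C(=O)C4(C(F)(F)F)CCCC4)CC3)CC2)cn1` gives 108 nM;
compound 3 `CS(=O)(=O)c1cnc(O[C@H]2CC[C@H](OC3CCN(CC4(C(F)(F)F)CCCC4)CC3)CC2)cn1` gives 101 nM.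

Compound 3 has the lowest of the three numbers, but only just: the step of a 1.1-fold lower number from compound 2 to compound 3 (0.03 log units; within the scatter) and the step of a 1.2-fold lower number from compound 1 to compound 3 (0.07 log units; within the scatter) are both within the scatter, so the three compounds cannot really be told apart on these numbers.

Compound 4 `CC(C)c1noc(CN2CCC(O[C@H]3CC[C@H](Oc4cnc(S(C)(=O)=O)cn4)CC3)CC2)n1` is the next compound, and it differs from compound 3 in one place: a group of 8 heavy atoms (5 carbon, 2 nitrogen, 1 oxygen; one five-membered aromatic ring with 3 hetero atoms) in place of a group of 9 heavy atoms (6 carbon, 3 fluorine; one five-membered non-aromatic ring of carbon only), on a saturated chain carbon bound to an amine nitrogen in a ring. Two of the measured steps change a group at this same ring nitrogen, a 1.2-fold lower number from compound 1 to compound 3 (0.07 log units; within the scatter) and a 1.1-fold lower number from compound 2 to compound 3 (0.03 log units; within the scatter), and the third, a 1.1-fold lower number from compound 1 to compound 2 (0.04 log units; within the scatter), changes a group on a nearby carbonyl carbon; all three are within the scatter. Among the measured compounds shown here, those steps swapped a carbamate, an amide and an alkyl group against one another, whereas compound 4 brings an aromatic ring with three hetero atoms to this place, which none of the measured compounds carries, so the comparison is looser than it looks. The expectation is therefore a step of a 1.3-fold higher number from compound 3 to compound 4 (0.11 log units; within the scatter), that is, nothing clearly beyond the scatter. For compound 4 the estimated value in this assay is 130 nM, with a range from 40 nM to 450 nM.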

Compound 4, half-maximal effective concentration: 97.9 nM
Beside the measured number, compound 4's estimate is 1.3-fold (0.12 log units) above it; measured number inside the range.
By their numbers in this assay, from the lowest: compounds 4, 3, 2 and 1 (each within the scatter of the next).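

In this assay, putting the 3-isopropyl-1,2,4-oxadiazol-5-yl group on a saturated chain carbon bound to an amine nitrogen in a ring gives a 1.0-fold lower number from compound 3 to compound 4 (0.01 log units; within the scatter), so an aromatic ring with three hetero atoms and three hydrogen-bond acceptors can stand where the group it replaces has a carbon-only ring and no acceptors, with no step beyond the scatter. The comparisons with the amide and the carbamate read the same way, with a 1.1-fold lower number from compound 2 to compound 4 (0.04 log units; within the scatter) and a 1.2-fold lower number from compound 1 to compound 4 (0.08 log units; within the scatter), so the four quite different substituents on this ring nitrogen cannot be told apart on this read-out. Nothing at hand explains why such different groups give readings this close.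

The compounds shown leave open how far this tolerance extends, for example to a carboxylic acid, a free amine or a longer chain between the ring nitrogen and the oxadiazole. They also do not show whether a group other than isopropyl on the oxadiazole would produce a step beyond the scatter.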